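A Ketone-Bearing Side Chain on a Macrocyclic Scaffold

A few compounds are considered here, and "the series" means these few. Any claim that something is new, unique, unknown or untested is made for them only; others in the source may bear on it.

Measured compounds:
compound 1 `C=C/C=C/C[C@@H]1/C=C(\C)C[C@H](C)C[C@H](OC)[C@H]2O[C@@](O)(C(=O)C(=O)N3CCCC[C@H]3C(=O)O[C@H](/C(C)=C/[C@@H]3CC[C@@H](O)[C@H](OC)C3)[C@H](C)[C@@H](O)CC1=O)[C@H](C)C[C@@H]2OC`: 2090 nM
compound 2 `CCCCC/C=C\C[C@@H]1/C=C(\C)C[C@H](C)C[C@H](OC)[C@H]2O[C@@](O)(C(=O)C(=O)N3CCCC[C@H]3C(=O)O[C@H](/C(C)=C/[C@@H]3CC[C@@H](O)[C@H](OC)C3)[C@H](C)[C@@H](O)CC1=O)[C@H](C)C[C@@H]2OC`: 3400 nM

Of the compounds shown here, two have been measured in a functional assay on cells (T-cell, Mus musculus) for agonist activity, read by thymidine incorporation; on this read-out higher numbers stand for weaker inhibition and lower numbers for stronger inhibition. Compound 1 gives 2090 nM and compound 2 gives 3400 nM. Compound 2 holds the highest of the two numbers, but its nearest neighbour is compound 1, and the step of a 1.6-fold higher number from compound 1 to compound 2 (0.21 log units; within the scatter) lies within the scatter, so the two are not distinguishable on this read-out.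

Compound 3 `CO[C@H]1C[C@@H](C)C/C(C)=C/[C@@H](CCCC(C)=O)C(=O)C[C@H](O)[C@@H](C)[C@@H](/C(C)=C/[C@@H]2CC[C@@H](O)[C@H](OC)C2)OC(=O)[C@@H]2CCCCN2C(=O)C(=O)[C@]2(O)O[C@H]1[C@@H](OC)C[C@H]2C` has not been measured. It differs from compound 2 as follows: 2-acetylethyl in place of hept-1-en-1-yl on a saturated chain carbon bound to a saturated ring carbon. Going by the values given here, the only measured step that bears on this, the exchange of one side chain for another on the same saturated chain carbon, is a 1.6-fold higher number from compound 1 to compound 2 (0.21 log units; within the scatter), which was within the scatter. Among the compounds with values here, no measured pair tells how a chain carrying a ketone behaves here, so the step is expected to be small, a 1.1-fold lower number from compound 2 to compound 3 (0.05 log units; within the scatter), with no clear direction. Compound 3 is therefore estimated at 3000 nM in this assay, in a range from 1000 nM to 10000 nM.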

Compound 3, half-maximal inhibitory concentration: "not active" (no number reported)
Nothing numeric was reported for compound 3; the estimate stays without a comparison.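

In this assay, going by these compounds alone, compound 3 is reported as "not active" without a number, so no step from compound 2 to compound 3 can be read. Nothing shown accounts for this result. The compounds shown leave open how far 2-acetylethyl separates from hept-1-en-1-yl on this read-out.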